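The source may hold more compounds than are shown below. What is called first, only, known or untested is meant among the compounds shown, and "the series" means these compounds.

Working notes on the thiocarbamate series. For the measured compounds named here, in a functional assay on HeLa cells (Homo sapiens) for antiproliferative activity, read by CCK-8 assay, with a stated time of 72 h, tested at 2 uM (on this read-out higher numbers stand for a stronger effect at the one concentration tested and lower numbers for a weaker effect), compound 2 `CC1CCCCN1C(=S)SCc1ccc(C(=O)Nc2ccccc2N)cc1` gives 45.5%, the higher of the two numbers so far; compound 1 `CN(C(=S)SCc1ccc(C(=O)Nc2ccccc2N)cc1)c1cccnc1` gives 16%. Going by the values given here, the single measured step, a number 29.5 percentage points higher from compound 1 to compound 2 (beyond the scatter), replaced methyl(pyridin-3-yl)amino with 2-methylpiperidin-1-yl. Compound 3 `CCN(Cc1ccncc1)C(=S)SCc1ccc(C(=O)Nc2ccccc2N)cc1` moves the other way: ethyl((pyridin-4-yl)methyl)amino in place of 2-methylpiperidin-1-yl on a thiocarbonyl carbon. Because a number 29.5 percentage points higher from compound 1 to compound 2 (beyond the scatter) shows the pyridine-bearing amine reading lower, a decrease beyond the scatter is expected for compound 3, although the ethyl and methylene make the comparison loose. Compound 3 is estimated at 27%, between 12% and 44%, an expected step of a number 18.5 percentage points lower from compound 2 to compound 3 (beyond the scatter).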

Compound 3, a percentage reported as inhibition, at one concentration (the size of the read-out at that concentration, not a potency): 63.5%
Beside the measured number, compound 3's estimate is 36.5 percentage points below it; measured number outside the range, above it.
By their numbers in this assay, from the lowest: compound 1; then compound 2; then compound 3.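

In this assay, ethyl((pyridin-4-yl)methyl)amino on the thiocarbonyl carbon gives a number 18 percentage points higher from compound 2 to compound 3 (beyond the scatter) and a number 47.5 percentage points higher from compound 1 to compound 3 (beyond the scatter). A pyridine ring in the amine therefore does not by itself go with a low reading: compound 1 and compound 3 both carry one, yet they stand at opposite ends of the three numbers. Nothing at hand explains this difference. As far as these compounds go, compound 1 and compound 3 differ in the alkyl group, the methylene and the pyridine attachment together, so which of these carries the step stays open. From the compounds shown here alone, how morpholin-4-yl would read on the same thiocarbonyl carbon also stays open.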